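Does a Dimethoxy Swap Change Antiproliferative Potency?

A few compounds are considered here, and "the series" means these few. Any claim that something is new, unique, unknown or untested is made for them only; others in the source may bear on it.

In a functional assay on A2780 cells (Homo sapiens) for antiproliferative activity, read by resazurin assay, with a stated time of 72 h (on this read-out higher numbers stand for weaker inhibition and lower numbers for stronger inhibition), compound 1 `Cc1ccccc1CN(C)C(=O)c1cc2c(Cc3ccccc3)n[nH]c2cc1O` gives 4400 nM and compound 2 `CCOc1ccc(CN(C)C(=O)c2cc3c(Cc4ccccc4)n[nH]c3cc2O)cc1` gives 3200 nM as its reading. Going by the values given here, these are the only two numbers so far, and the one measured step, a 1.4-fold lower number from compound 1 to compound 2 (0.14 log units; within the scatter), came from placing 4-ethoxyphenyl where 2-methylphenyl had been. Compound 2 therefore stands level with compound 1, not clearly ahead of it.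

Compound 3 `COc1cccc(CN(C)C(=O)c2cc3c(Cc4ccccc4)n[nH]c3cc2O)c1OC` keeps the shared core and changes that same spot, on a saturated chain carbon bound to an amide-type nitrogen. The change, (2,3-dimethoxyphenyl in place of 4-ethoxyphenyl on a saturated chain carbon bound to an amide-type nitrogen), swaps one substituted phenyl group for another.

Among the compounds with values here, no measured compound carries a dimethoxyphenyl group, so the evidence is thin. Within the data shown here, the only guide is the swap from compound 1 to compound 2, and its step of a 1.4-fold lower number from compound 1 to compound 2 (0.14 log units; within the scatter) stayed small. A similar swap should therefore cause no shift beyond the scatter in this assay here. The expected change is a 1.1-fold higher number from compound 2 to compound 3 (0.04 log units; within the scatter) on this reasoning. For compound 3 the estimated value is 3500 nM with an expected range of 1500 nM to 8000 nM in this assay.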

Compound 3, half-maximal inhibitory concentration: 4800 nM
Compound 3: middle estimate off by 1.4-fold (0.14 log units), on the low side; the measured number falls inside the stated range.
By their numbers in this assay, from the lowest: compounds 2, 1 and 3 (each within the scatter of the next).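

At this spot, on a saturated chain carbon bound to an amide-type nitrogen, a third substituted phenyl group now reads level with the other two in this assay: placing 2,3-dimethoxyphenyl on it gives a 1.5-fold higher number from compound 2 to compound 3 (0.18 log units; within the scatter) and, against the methyl-bearing ring, a 1.1-fold higher number from compound 1 to compound 3 (0.04 log units; within the scatter). Going by these compounds alone, the earlier pair compared only two groups, whereas this result adds one with 2 hydrogen-bond acceptors against 1 for 4-ethoxyphenyl, and 2-methylphenyl, 4-ethoxyphenyl and 2,3-dimethoxyphenyl still cannot be told apart in this read-out. No measurement is available that would explain why these readings stay together.

All three groups shown are phenyl rings with no net charge, so it remains open whether a ring carrying an amine or a carboxylic acid, or a longer chain between the ring and the amide-type nitrogen, would move the number beyond the scatter. Going by these compounds, it also remains open whether a single methoxy group on the ring would read any differently from the two in compound 3.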